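A few compounds are considered here, and "the series" means these few. Any claim that something is new, unique, unknown or untested is made for them only; others in the source may bear on it.

Compound 1, `COC(=O)c1c(-c2ccc([N+](=O)[O-])cc2)oc2ccccc2c1=O`, in a functional assay on Malme-3M cells (Homo sapiens) for cytotoxicity, read by MTT assay, with a stated time of 6 days (on this read-out higher numbers stand for an effect only at larger amounts of compound and lower numbers for an effect already at smaller amounts), gives > 25 ug/mL, a limit of the assay rather than a number. Compound 2, `COC(=O)c1c(-c2ccc([N+](=O)[O-])cc2)oc2cc(OC)ccc2c1=O`, gives 1.12 ug/mL. Compound 3, `COC(=O)c1c(-c2ccc(O)cc2)oc2ccccc2c1=O`, gives > 25 ug/mL, again only a limit.

The change from compound 1 to compound 2 is methoxy in place of hydrogen on an aromatic carbon, and it brought an at least 22-fold lower number from compound 1 to compound 2 (1.34 log units; beyond the scatter). Compound 3 differs from compound 1 by hydroxy in place of nitro on an aromatic carbon, but with both values sitting at the limit, the step that the two limits leave unreadable from compound 1 to compound 3. As far as these compounds go, the shared limit is the limit of > 25 ug/mL in this assay, at which 2 of the 3 values shown sit, so where compound 3 truly lies remains open.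

Compound 4, `COC(=O)c1c(-c2ccc(O)cc2)oc2ccc(OC)cc2c1=O`, has not yet been measured in this assay. It differs from compound 3 by methoxy in place of hydrogen on an aromatic carbon, the same change as from compound 1 to compound 2, at a place described in the same words. Since that earlier change gave an at least 22-fold lower number from compound 1 to compound 2 (1.34 log units; beyond the scatter), a step of similar direction is expected here, though the limit on compound 3 leaves its size uncertain. The estimated step is an at least 6.2-fold lower number from compound 3 to compound 4 (0.79 log units; beyond the scatter). Compound 4 is expected to give about 4 ug/mL, with a plausible range from 1 ug/mL to 25 ug/mL.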

Compound 4, concentration for half-maximal effect: > 25 ug/mL
Compound 4 gave a limit, no number; the forecaster's own chance of this, stated with the estimate: 35%; at least 6.2-fold (0.79 log units) between middle value and limit.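

Compound 3 and compound 4 both give only a limit in this assay, so no step can be read between them: the limit of > 25 ug/mL in this assay, at which 3 of the 4 values shown sit.

The compounds shown leave open where compound 3 and compound 4 truly lie, and whether methoxy in place of hydrogen on an aromatic carbon changes the number at all when hydroxy replaces nitro.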